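A few compounds are considered here, and "the series" means these few. Any claim that something is new, unique, unknown or untested is made for them only; others in the source may bear on it.

Working notes on the series. In a functional assay on SNB-19 cells (Homo sapiens) for inhibition, read by sulforhodamine B assay, with a stated time of 48 h (a higher number here means a weaker inhibitor of growth, a lower number a stronger inhibitor of growth), compound 1 (`O=C(Cc1csc2nc(-c3ccc(Br)cc3)cn12)N/N=C/c1ccccc1`) gives 43700 nM and compound 2 (`O=C(Cc1csc2nc(-c3ccc(Br)cc3)cn12)N/N=C/c1ccc(O)cc1`) gives 57500 nM while compound 3 (`COc1cccc(OC)c1/C=N/NC(=O)Cc1csc2nc(-c3ccc(Br)cc3)cn12`) gives 31600 nM on the same read-out. Compound 3 does not stand apart from the other two. The measured changes at this part of the molecule give a 1.4-fold lower number from compound 1 to compound 3 (0.14 log units; within the scatter) and a 1.8-fold lower number from compound 2 to compound 3 (0.26 log units; within the scatter) together with a 1.3-fold higher number from compound 1 to compound 2 (0.12 log units; within the scatter) for hydroxy in place of hydrogen on an aromatic carbon. Compound 4 (`O=C(Cc1csc2nc(-c3ccc(Br)cc3)cn12)N/N=C/c1ccc(Cl)cc1Cl`) is still unmeasured and is defined by this difference: 2,4-dichlorophenyl in place of 2,6-dimethoxyphenyl on a carbon with a double bond to nitrogen on a carbon with a double bond to nitrogen. Going by the values given here, no measured compound carries chlorine, and these steps bear on the change only as a guide to its likely size. None of the three steps leaves the scatter, and no step beyond the scatter is expected in this assay here. The estimated step is a 1.1-fold higher number from compound 3 to compound 4 (0.06 log units; within the scatter) with no clear direction expected. Compound 4 is expected at 36000 nM with an estimated range of 17000 nM to 75000 nM in this read-out.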

Compound 4, concentration for 50% growth inhibition: 95500 nM
For compound 4 the middle estimate is 2.7-fold (0.42 log units) below the measured one; the measured number lies above the stated range.
By their numbers in this assay, from the lowest: compounds 3, 1, 2 and 4 (each within the scatter of the next, the first and the last beyond it).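

In this assay, the place on a carbon with a double bond to nitrogen had given only steps within the scatter, but 2,4-dichlorophenyl now gives steps beyond it: a 3.0-fold higher number from compound 3 to compound 4 (0.48 log units; beyond the scatter) in place of 2,6-dimethoxyphenyl and a 2.2-fold higher number from compound 1 to compound 4 (0.34 log units; beyond the scatter) in place of phenyl. Compound 2 goes against a clean separation of 2,4-dichlorophenyl from the other groups, since a 1.7-fold higher number from compound 2 to compound 4 (0.22 log units; within the scatter) in place of 4-hydroxyphenyl. No measurement is available that would explain this change.

The compounds shown leave open whether the change follows from one chlorine or needs both. They also leave open what an amine or a carboxylic acid on the phenyl ring would give at this place, and whether any group here can move the number lower than the scatter allows.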